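Phenyl for tert-Butyl Repeated on a Second Core

The source may report more compounds than this note shows. Statements on the series, on what has been measured and on what is new or still open speak of the compounds shown alone.

Measured so far:
Compound 1, `CC(C)(C)C(=O)Nc1nc(CN=C=S)cs1`, gives 4300 nM in a functional assay on L1210 cells (Mus musculus) for antiproliferative activity; on this read-out higher numbers stand for weaker inhibition and lower numbers for stronger inhibition.
Compound 2, `O=C(Nc1nc(CN=C=S)cs1)c1ccccc1`, gives 200 nM in this assay.
Compound 3, `CC(C)(C)C(=O)Nc1nc(CN=C=S)c[se]1`, gives 18000 nM in this assay.

Compounds 1 and 2 share one core and differ in a single place: phenyl in place of tert-butyl on a carbonyl carbon. In this assay that change made a 22-fold lower number from compound 1 to compound 2 (1.33 log units; beyond the scatter). Compound 3 carries a different core; how the core of compound 1 and the core of compound 3 differ is not broken down here. Compound 3 has the highest number of the three measured compounds, and its gap to each of the others lies beyond the scatter.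

Compound 4, `O=C(Nc1nc(CN=C=S)c[se]1)c1ccccc1`, has not yet been measured. It relates to compound 3 as compound 2 relates to compound 1: phenyl in place of tert-butyl on a carbonyl carbon. The surroundings of the place are the same in both pairs, so this is the same change. Going by the values given here, only one earlier example exists, on a different core, so the expected step is a 20-fold lower number from compound 3 to compound 4 (1.30 log units; beyond the scatter) in this assay, resting on the step from compound 1 to compound 2. For compound 4 the expected value in this assay is 900 nM, estimated between 300 nM and 3000 nM.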

Compound 4, half-maximal inhibitory concentration: 900 nM
The estimate for compound 4 equals the measured number at the digits printed; the range from low to high includes it.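

In this assay, phenyl in place of tert-butyl on the carbonyl carbon gives a 20-fold lower number from compound 3 to compound 4 (1.30 log units; beyond the scatter), a large step on the second core. Set beside the earlier step, the change carries over from one core to the other with its size kept: the same change on two cores in this assay, a 22-fold lower number (1.33 log units; beyond the scatter) from compound 1 to compound 2 and a 20-fold lower number (1.30 log units; beyond the scatter) from compound 3 to compound 4, 1.1-fold (0.03 log units) apart, within the scatter of two such steps This shows only that one change behaved alike on two cores in one cell assay; it does not explain why the number falls, and two cores are too few to predict the step on a third.

The compounds shown compare only tert-butyl and phenyl, so they leave open whether a cyclohexyl ring, a pyridine ring or a short chain such as methyl on the same carbonyl carbon would give a similar step. As far as these compounds go, it also remains open whether a substituted phenyl, for example one carrying a methoxy group or a chlorine atom, would lower the number further or raise it again on either core.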